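Fluorine Added to a Compound Showing No Measurable Inhibition

The source may hold more compounds than are shown below. What is called first, only, known or untested is meant among the compounds shown, and "the series" means these compounds.

Compound 1 `O/N=C(/Nc1ccccc1)c1ccc2occc2c1` was tested in an assay on isolated protein for inhibition of Indoleamine 2,3-dioxygenase 1 (Homo sapiens), read by spectrophotometry; a higher number here means a weaker inhibitor, a lower number a stronger inhibitor. In this assay, from the compounds shown here alone, compound 1 gives only a limit, > 30000 nM, so its true potency is unknown beyond that point. Compound 2 `O/N=C(/Nc1ccc(Cl)cc1)c1ccc2occc2c1` carries chloro in place of hydrogen on an aromatic carbon. In this assay compound 2 also gives only a limit, > 30000 nM. The step that the two limits leave unreadable from compound 1 to compound 2 cannot be read, since (the limit of > 30000 nM in this assay, at which 2 of the 2 values shown sit). Compound 3 `O/N=C(/Nc1cccc(F)c1)c1ccc2occc2c1` differs from compound 1 by fluoro in place of hydrogen on an aromatic carbon. Among the measured compounds shown here, the only measured step that bears on this change is the halogen step from compound 1 to compound 2, whose size is not readable, so no direction of change in this assay is supported. The step is estimated as a step that the limit leaves unreadable from compound 1 to compound 3. Compound 3 is expected to give about 50000 nM, within a range from 15000 nM to 200000 nM, most likely reported again only as a limit.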

Compound 3, half-maximal inhibitory concentration: 32700 nM
Compound 3: middle estimate off by 1.5-fold (0.18 log units), on the high side; the measured number falls inside the stated range.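

No step can be read from compound 1 to compound 3, since compound 1 is known only as a limit: the limit of > 30000 nM in this assay, at which 2 of the 3 values shown sit.

The compounds shown leave open how strong compound 1 truly is, and so whether fluoro or chloro in place of hydrogen changes inhibition at all.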